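Sulfonamide aryl variation on the fluorocyclopentyl acid core

This account rests on a few compounds, and the source may have more. Where it says the series, first, only, none or still open, it means among the compounds named here.

Compound 1 `O=C(O)CCC/C=C\C[C@H]1[C@H](F)CC[C@@H]1NS(=O)(=O)c1ccccc1[N+](=O)[O-]`: 1800 nM
Compound 2 `O=C(O)CCC/C=C\C[C@H]1[C@H](F)CC[C@@H]1NS(=O)(=O)c1ccc(F)cc1`: 540 nM; 540 nM (2 entries)

In a functional assay on a cell-free system (plasma) for inhibition of thromboxane A2 receptor (Homo sapiens), read by turbidimetry (on this read-out higher numbers stand for weaker inhibition and lower numbers for stronger inhibition), compound 1 gives 1800 nM, the higher of the two values shown; compound 2 gives 540 nM; 540 nM (2 entries). Compound 3 `O=C(O)CCC/C=C\C[C@H]1[C@H](F)CC[C@@H]1NS(=O)(=O)c1ccc(Cl)c(Cl)c1` differs from compound 1 by 3,4-dichlorophenyl in place of 2-nitrophenyl on a sulfonyl sulfur. Among the measured compounds shown here, no measured pair isolates this change, so the size of the step is uncertain; the values of compound 1 and compound 2 show that the aryl group on the sulfonyl sulfur does move the number in this assay. A moderate gain toward the range of compound 2 is expected, with the step of a 4.0-fold lower number from compound 1 to compound 3 (0.60 log units; beyond the scatter). For compound 3 the expected value is 450 nM, estimated between 130 nM and 1600 nM.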

Compound 3, half-maximal inhibitory concentration: 630 nM
Compound 3: the middle estimate sits 1.4-fold (0.15 log units) below what was measured; low and high end bracket the measured number.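

In this assay, among the compounds shown here, 3,4-dichlorophenyl in place of 2-nitrophenyl on a sulfonyl sulfur gives a 2.9-fold lower number from compound 1 to compound 3 (0.46 log units; beyond the scatter), the first step at this position that can be read directly. Compound 2 at 540 nM; 540 nM (2 entries) and compound 3 at 630 nM lie within the usual scatter of each other, so these two aryl groups are not told apart here. Nothing measured here accounts for the step. Still open, going by these compounds, is whether the step follows from losing 2-nitrophenyl or from gaining the chlorines. An unsubstituted phenyl or a 4-methoxyphenyl on the sulfonyl sulfur would separate the two.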